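Working notes: 1,3-oxazol-2-yl in place of pyrazin-2-yl

A few compounds are considered here, and "the series" means these few. Any claim that something is new, unique, unknown or untested is made for them only; others in the source may bear on it.

Measured so far in a physicochemical assay for solubility, in phosphate buffer, with a stated time of 18 h; on this read-out higher numbers stand for higher solubility and lower numbers for lower solubility:
- compound 1 `CC(C)(C)c1nc(C2CCCC2)c2c(N)c(C#N)c(N)nc2n1`: < 1000 nM (a limit)
- compound 2 `CC(C)(C)c1nc(-c2cnccn2)c2c(N)c(C#N)c(N)nc2n1`: 86000 nM

For the measured compounds named here, compound 2 holds the only actual number, 86000 nM. The next compound to be measured is compound 3 `CC(C)(C)c1nc(-c2ncco2)c2c(N)c(C#N)c(N)nc2n1`, with 1,3-oxazol-2-yl in place of pyrazin-2-yl on an aromatic carbon.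

Going by the values given here, the one measured step is an at least 86-fold higher number from compound 1 to compound 2 (1.93 log units; beyond the scatter), with pyrazin-2-yl in place of cyclopentyl on an aromatic carbon. Compound 3 keeps an aromatic ring at the place where an at least 86-fold higher number from compound 1 to compound 2 (1.93 log units; beyond the scatter) brought one in, so a step of that size is not expected in this assay. The expectation is a small step, downward if anything, and possibly none beyond the scatter. The expected step is a 1.4-fold lower number from compound 2 to compound 3 (0.16 log units; within the scatter). For compound 3 the estimated value is 60000 nM, with an expected range of 18000 nM to 170000 nM.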

Compound 3, solubility: 50000 nM
For compound 3 the middle estimate is 1.2-fold (0.08 log units) above the measured one; measured number inside the range.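

In this assay, 1,3-oxazol-2-yl in place of pyrazin-2-yl gives a 1.7-fold lower number from compound 2 to compound 3 (0.24 log units; within the scatter), so this position, opposite the ring nitrogen, does not separate a five-membered from a six-membered aromatic ring with 2 hetero atoms. Against cyclopentyl, the new group gives an at least 50-fold higher number from compound 1 to compound 3 (1.69 log units; beyond the scatter), so a large step at this position is now seen with two aromatic rings and is not tied to pyrazin-2-yl alone. The size of that step is only a bound, since the value of compound 1 is a limit and not a number: the limit of < 1000 nM in this assay, at which 1 of the 3 values shown sits.

Both aromatic groups shown carry 2 hetero atoms, so the reading of this assay with a plain phenyl ring at this position remains open. Also open, as far as these compounds go, is whether a saturated ring with hetero atoms, such as morpholine, would behave like cyclopentyl or like the aromatic groups.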